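The source may hold more compounds than are shown below. What is called first, only, known or untested is meant among the compounds shown, and "the series" means these compounds.

Compound 1, `Clc1ccc(Nc2ccc(N3CC4CC(C3)N4)nn2)cc1Cl`: 516 nM. Compound 2, `CN(c1ccccc1)c1ccc(N2CC3CC(C2)N3)nn1`: 1430 nM.

In an assay on cell membranes for displacement of a labelled ligand from Neuronal acetylcholine receptor; alpha4/beta2 (Rattus norvegicus) (on this read-out lower numbers stand for stronger inhibition and higher numbers for weaker inhibition), compound 1 gives 516 nM, while compound 2 gives 1430 nM. Compound 1 therefore stands with the lower of the two numbers, and the gap between compound 1 and compound 2 lies beyond the usual scatter of this assay. Compound 3, `Clc1cccc(Nc2ccc(N3CC4CC(C3)N4)nn2)c1`, has not yet been measured. It differs from compound 1 in a single place: hydrogen in place of chloro on an aromatic carbon. Going by the values given here, no measured pair in this set shows what such a change does, so there is no measured step to lean on. The author expects the number for compound 3 in this assay to rise relative to compound 1, a moderate step that lies beyond the scatter but does not reach the level of compound 2. The expected step of a 2.3-fold higher number from compound 1 to compound 3 (0.37 log units; beyond the scatter) reflects that view. Compound 3 is thus expected to give 1200 nM, with a likely range from 450 nM to 3200 nM.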

Compound 3, inhibition constant: 1540 nM
Compound 3: the middle estimate sits 1.3-fold (0.11 log units) below what was measured; low and high end bracket the measured number.
By their numbers in this assay, from the lowest: compound 1; then compounds 2 and 3 (each within the scatter of the next).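

In this assay, hydrogen in place of chloro on this aromatic carbon, which is ortho to a chloro group and para to a large group, gives a 3.0-fold higher number from compound 1 to compound 3 (0.47 log units; beyond the scatter). Going by these compounds alone, this is the first single-place step in the set, and it shows that this chloro group contributes to the number of compound 1: the other chloro group, which compound 3 keeps, does not preserve that number on its own. No measurement shown here accounts for the size of this step.

The compounds shown leave open whether a chloro group is specifically required on this carbon, or whether a fluoro, methyl or methoxy group there would restore the number of compound 1. They also leave open what replacing the other chloro group with hydrogen would do.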